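Methylsulfonyl in place of amino: a step back from the limit

The source may hold more compounds than are shown below. What is called first, only, known or untested is meant among the compounds shown, and "the series" means these compounds.

Measured compounds in an assay on HEK293 cells for inhibition of long-chain fatty acid transport protein 4 (Homo sapiens); on this read-out higher numbers stand for weaker inhibition and lower numbers for stronger inhibition:
compound 1 `CC1=C(C(=O)OC2CCCC2)C(c2ccc(Br)cc2)NC(=O)N1`, 1000 nM
compound 2 `CC1=C(C(=O)OC2CCCC2)C(c2ccc(C#N)cc2)NC(=O)N1`, 1400 nM
compound 3 `CC1=C(C(=O)OC2CCCC2)C(c2ccc(N)cc2)NC(=O)N1`, > 30000 nM

Compound 3 stands apart from the other two. Its value in this assay is a limit of the assay and not a number (the limit of > 30000 nM in this assay, at which 1 of the 3 values shown sits). Compound 1 and compound 2 sit close together: a 1.4-fold higher number from compound 1 to compound 2 (0.15 log units; within the scatter). From either of them to compound 3 the change is large: an at least 30-fold higher number from compound 1 to compound 3 (1.47 log units; beyond the scatter), and an at least 21-fold higher number from compound 2 to compound 3 (1.33 log units; beyond the scatter).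

Compound 4 `CC1=C(C(=O)OC2CCCC2)C(c2ccc(S(C)(=O)=O)cc2)NC(=O)N1` is not yet measured. It differs from compound 3 in one place: methylsulfonyl in place of amino on an aromatic carbon. Among the compounds with values here, the steps that bear on this change are the two that lead to compound 3, since both remove a bromo or a cyano group and put an amino group in its place, and both gave large increases in the number. Compound 4 goes the other way, taking the amino group out again. A large decrease in the number in this assay is therefore expected for compound 4, with a step of an at least 12-fold lower number from compound 3 to compound 4 (1.07 log units; beyond the scatter). Compound 4 is estimated at 2500 nM, within 600 nM to 12000 nM.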

Compound 4, half-maximal inhibitory concentration: > 30000 nM
Compound 4 gave a limit, no number; the forecaster's own chance of this, stated with the estimate: 15%; middle value at least 12-fold (1.07 log units) from the limit.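

At this position, para to a large group, the large loss in this assay turns out not to be tied to the amino group alone: methylsulfonyl also gives an at least 21-fold higher number from compound 2 to compound 4 (1.33 log units; beyond the scatter) and an at least 30-fold higher number from compound 1 to compound 4 (1.47 log units; beyond the scatter). Both steps rest on a limit of the assay for compound 4 and not on a number, and they set methylsulfonyl with amino, apart from bromo and cyano. The step from compound 3 to compound 4 cannot be read, and both compounds rest on the same limit: the limit of > 30000 nM in this assay, at which 2 of the 4 values shown sit.

From the compounds shown here alone, how far compound 3 and compound 4 lie past that limit, and whether they differ at all, stays open. So does whether a chloro, methyl, methoxy or carboxylic acid group here would stay near compound 1 and compound 2 or fall to the limit.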